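A flat series meets a new side group

The source may report more compounds than this note shows. Statements on the series, on what has been measured and on what is new or still open speak of the compounds shown alone.

In a functional assay on MCF7 cells (Homo sapiens) for inhibition, read by MTT assay, with a stated time of 48 h (a higher number here means a weaker inhibitor, a lower number a stronger inhibitor), compound 1 `CCOC(=O)C1=C(N/N=C(\C#N)C(N)=O)Nc2[nH]nc(C)c2C1c1ccc(N(C)C)cc1` gives 50100 nM, compound 2 `CCOC(=O)C1=C(N/N=C(/Cl)c2ccc([N+](=O)[O-])cc2)Nc2[nH]nc(C)c2C1c1ccc(N(C)C)cc1` gives 52700 nM and compound 3 `CCOC(=O)C1=C(N/N=C(/Br)c2ccccc2)Nc2[nH]nc(C)c2C1c1ccc(N(C)C)cc1` gives 78400 nM. Compound 3 therefore stands level with the other two, as a 1.6-fold higher number from compound 1 to compound 3 (0.19 log units; within the scatter) and a 1.5-fold higher number from compound 2 to compound 3 (0.17 log units; within the scatter) show. Compound 4 `CCOC(=O)C1=C(N/C=N/c2ccccn2)Nc2[nH]nc(C)c2C1c1ccc(N(C)C)cc1` differs from compound 3 on the amine nitrogen: a group of 8 heavy atoms (6 carbon, 2 nitrogen; one six-membered aromatic ring with 1 hetero atom) in place of a group of 9 heavy atoms (7 carbon, 1 nitrogen, 1 bromine; one six-membered aromatic ring of carbon only), on an amine nitrogen. The measured steps changed the group at that same place, and the third of them, a 1.1-fold higher number from compound 1 to compound 2 (0.02 log units; within the scatter), is equally small. For the measured compounds named here, none of the measured compounds carries a six-membered aromatic ring with 1 hetero atom, so this guide is imperfect. Even so, no step beyond the scatter is expected in this assay. The expected change is a 1.4-fold lower number from compound 3 to compound 4 (0.15 log units; within the scatter). For compound 4 the estimated value is 55000 nM, with an expected range of 15000 nM to 120000 nM.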

Compound 4, half-maximal inhibitory concentration: 37300 nM
Beside the measured number, compound 4's estimate is 1.5-fold (0.17 log units) above it; low and high end bracket the measured number.
By their numbers in this assay, from the lowest: compounds 4, 1, 2 and 3 (each within the scatter of the next, the first and the last beyond it).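

For the compounds shown here, the group with a six-membered aromatic ring with 1 hetero atom gives the first step at this amine nitrogen that lies beyond the scatter (a 2.1-fold lower number from compound 3 to compound 4 (0.32 log units; beyond the scatter)). It does not set compound 4 apart from the others, since two steps stay within the scatter (a 1.4-fold lower number from compound 2 to compound 4 (0.15 log units; within the scatter); a 1.3-fold lower number from compound 1 to compound 4 (0.13 log units; within the scatter)), so the series remains close to flat. Going by these compounds alone, no available evidence accounts for the one modest step. Still open, on these data alone, is whether a carboxylic acid or a longer chain on this amine nitrogen would move the number any further.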